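A new aromatic group on a shared core

A few compounds are considered here, and "the series" means these few. Any claim that something is new, unique, unknown or untested is made for them only; others in the source may bear on it.

Measured so far in a physicochemical assay for solubility, in phosphate buffer, measured as kinetic solubility, at pH 7.4; a lower number here means a less soluble compound, a higher number a more soluble compound:
Compound 1 `Cc1oc(-c2ccc(Cl)cc2)nc1CN1CCC(C(=O)NCCCN2C[C@H](C)C[C@H](C)C2)CC1`: > 72 ug/mL
Compound 2 `COc1ccc(-c2nc(CN3CCC(C(=O)NCCCN4C[C@H](C)C[C@H](C)C4)CC3)c(C)o2)cc1OC`: > 76 ug/mL

In this assay compound 2 stands at > 76 ug/mL, which is a limit and not a number. Compound 1 gives > 72 ug/mL, and this too is a limit. No exact value is therefore available for either compound.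

Compound 3 `Cc1cc(C)cc(-c2nc(CN3CCC(C(=O)NCCCN4C[C@H](C)C[C@H](C)C4)CC3)c(C)o2)c1` has not yet been measured. It differs from compound 2 at one place, with 3,5-dimethylphenyl in place of 3,4-dimethoxyphenyl on an aromatic carbon.

For the measured compounds named here, the one measured step that bears on this change is a step that the two limits leave unreadable from compound 1 to compound 2. It has no readable size, so it offers no measured effect to carry over. Both groups tested at this place gave limits rather than numbers, so no step beyond the scatter is expected in this assay, and no direction can be assigned. For compound 3 the expected step is an at least 1.0-fold lower number from compound 2 to compound 3 (0.03 log units; that floor lies within the scatter), an estimate that stays within the scatter. The estimated value for compound 3 is 70 ug/mL, with an expected range from 35 ug/mL to 76 ug/mL.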

Compound 3, solubility: > 71 ug/mL
Compound 3 ended at the assay's limit; the forecaster's own chance of this, stated with the estimate: 75%; at least 1.0-fold (0.00 log units) between middle value and limit.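

In this assay compound 3 gives > 71 ug/mL, which is a limit and not a number. Compound 1 and compound 2 also have only limits, and none of the steps among these three compounds can be read. The compounds shown leave open their exact values, and whether the three aromatic groups differ at all in this assay.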